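The source may report more compounds than this note shows. Statements on the series, on what has been measured and on what is new or still open speak of the compounds shown alone.

Measured compounds:
compound 1, `COc1ccc(Nc2ncc(C(F)(F)F)c(N3Cc4cccc(N(C)S(C)(=O)=O)c4C3)n2)cc1C(F)(F)F`: > 30000 nM in a functional assay on HepG2 cells (Homo sapiens) for antiproliferative activity, read by spectrophotometry, with a stated time of 2 days; a lower number here means a stronger inhibitor of growth, a higher number a weaker inhibitor of growth (a limit)
compound 2, `Cc1cc(F)ccc1Nc1ncc(C(F)(F)F)c(N2Cc3cccc(N(C)S(C)(=O)=O)c3C2)n1`: 16800 nM in this assay

Compound 1 returns only a limit in this assay, not a number. Among the measured compounds shown here, compound 2 is therefore the only compound with a number; the other value shown is a limit (the limit of > 30000 nM in this assay, at which 1 of the 2 values shown sits). For the measured compounds named here, the single measured step, an at least 1.7-fold lower number from compound 1 to compound 2 (0.25 log units; that floor lies within the scatter), has a limit at one end, and its floor lies within the scatter, so it sets no firm size or direction for swapping the aryl group on the amine nitrogen; it shows only that growth inhibition stays weak across such a swap.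

Compound 3 `CN(c1cccc2c1CN(c1nc(Nc3cccc(C(F)(F)F)c3)ncc1C(F)(F)F)C2)S(C)(=O)=O` differs from compound 2 by 3-(trifluoromethyl)phenyl in place of 4-fluoro-2-methylphenyl on a nitrogen on an aromatic ring. Going by the values given here, the one measured step concerns this same position and is the only step that bears on the change. With no measured step beyond the scatter at this position, no step beyond the scatter is expected here either: the expected step is a 1.1-fold lower number from compound 2 to compound 3 (0.02 log units; within the scatter). Compound 3 is estimated at 16000 nM in this assay, with a range from 5000 nM to 45000 nM, and a limit report remains possible.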

Compound 3, concentration for 50% growth inhibition: > 30000 nM
Compound 3 was reported as a limit (the forecaster's own chance of this, stated with the estimate: 30%); middle value at least 1.8-fold (0.27 log units) from the limit.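

In this assay compound 3 gives only a limit, > 30000 nM, and not a number. Among the compounds shown here, the step reads an at least 1.7-fold higher number from compound 2 to compound 3 (0.25 log units; that floor lies within the scatter), so it sets no firm size, but it adds 3-(trifluoromethyl)phenyl to the aryl groups on this nitrogen that give no sign of stronger growth inhibition, and 4-fluoro-2-methylphenyl in compound 2 remains the only group here with a number. The step between compound 1 and compound 3 cannot be read, as both ends are limits, and the limit is now the commonest result at this position: the limit of > 30000 nM in this assay, at which 2 of the 3 values shown sit.

Still open, as far as these compounds go, is whether any group on this nitrogen can give a number clearly lower than that of compound 2, for instance a phenyl ring carrying an amine or a carboxylic acid, or a saturated alkyl chain in place of the aryl ring. Also open, from the compounds shown here alone, is whether a change elsewhere, such as replacing the methanesulfonyl group on the shared core with an acetyl group, would move the value at all.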